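Phenoxy in place of isopropoxy on the shared core

This account rests on a few compounds, and the source may have more. Where it says the series, first, only, none or still open, it means among the compounds named here.

Three analogues on one core have been measured in a functional assay for inhibition of sodium/hydrogen exchanger (Oryctolagus cuniculus); a lower number here means a stronger inhibitor, a higher number a weaker inhibitor. Compound 1 `Cc1cc(Sc2ccc(Cl)cc2)c(S(C)(=O)=O)cc1C(=O)N=C(N)N` gives 19 nM; compound 2 `Cc1cc(Sc2ccccc2)c(S(C)(=O)=O)cc1C(=O)N=C(N)N` gives 14 nM; compound 3 `Cc1cc(OC(C)C)c(S(C)(=O)=O)cc1C(=O)N=C(N)N` gives 19 nM. Compound 3 stands level with compound 1 at the digits printed, the two together being the highest numbers of the three, and its gap to compound 2 is within the scatter, as a 1.4-fold higher number from compound 2 to compound 3 (0.13 log units; within the scatter) shows. The whole set spans less than the scatter: a 1.4-fold lower number from compound 1 to compound 2 (0.13 log units; within the scatter) and no change at the digits printed from compound 1 to compound 3 (within the scatter) are both within it.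

Compound 4 `Cc1cc(Oc2ccccc2)c(S(C)(=O)=O)cc1C(=O)N=C(N)N` differs from compound 3 by phenyl in place of isopropyl on an oxygen on an aromatic ring. Going by the values given here, the steps that bear on this are the swaps at the same place on the core, a 1.4-fold higher number from compound 2 to compound 3 (0.13 log units; within the scatter) and no change at the digits printed from compound 1 to compound 3 (within the scatter), both within the scatter, and no measured pair changes a group on that oxygen itself. The expected outcome in this assay is therefore no step beyond the scatter, a 1.1-fold lower number from compound 3 to compound 4 (0.05 log units; within the scatter). Compound 4 is estimated at 17 nM, with a range of 7 nM to 45 nM.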

Compound 4, half-maximal inhibitory concentration: 10 nM
Estimate against measurement, compound 4: 1.7-fold (0.23 log units) above; low and high end bracket the measured number.
By their numbers in this assay, from the lowest: compounds 4, 2, 1 and 3 (each within the scatter of the next).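

In this assay, the oxygen on an aromatic ring carries phenyl as readily as isopropyl, with a 1.9-fold lower number from compound 3 to compound 4 (0.28 log units; within the scatter) showing no separation beyond the scatter despite the entry of an aromatic ring. Exchanging the sulfur link for oxygen also leaves the numbers within the scatter, with a 1.4-fold lower number from compound 2 to compound 4 (0.15 log units; within the scatter) and a 1.9-fold lower number from compound 1 to compound 4 (0.28 log units; within the scatter), so all four groups at this place, with or without a ring, read alike here. No accompanying evidence bears on this result.

Still open, going by these compounds, is whether an amine or a carboxylic acid at this place would give a step beyond the scatter. The same question stands for a longer chain on the oxygen and for chloro on the phenyl of compound 4.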